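The source may hold more compounds than are shown below. What is called first, only, known or untested is meant among the compounds shown, and "the series" means these compounds.

In a functional assay on SK-MEL-28 cells (Homo sapiens) for inhibition, read by MTT assay, with a stated time of 72 h (a higher number here means a weaker inhibitor of growth, a lower number a stronger inhibitor of growth), compound 1 `CC(C)(C)OC(=O)/C=C/C1=CC[C@H]2C(C)(C)CCC[C@]2(C)[C@H]1C=O` gives 41000 nM and compound 2 `CC1(C)CCC[C@]2(C)[C@@H](C=O)C(/C=C/C#N)=CC[C@@H]12` gives 42000 nM on the same core. Among the compounds with values here, compound 2 therefore stands level with compound 1, the only other compound measured, and the step of a 1.0-fold higher number from compound 1 to compound 2 (0.01 log units; within the scatter) lies within the scatter. Compound 3 `CC(=O)/C=C/C1=CC[C@H]2C(C)(C)CCC[C@]2(C)[C@H]1C=O` is compound 2 with one group exchanged, as acetyl in place of cyano on a double-bonded chain carbon bound to a double-bonded chain carbon shows: acetyl in place of cyano on a double-bonded chain carbon bound to a double-bonded chain carbon. Within the data shown here, only one measured step bears on this exchange, since tert-butoxycarbonyl and cyano sit at that same place and read alike. Among the measured compounds shown here, that is thin evidence, and no measured compound yet carries acetyl there. Resting on the step of a 1.0-fold higher number from compound 1 to compound 2 (0.01 log units; within the scatter) as the only guide, no step beyond the scatter is expected in this assay in either direction. The expected step is a 1.1-fold lower number from compound 2 to compound 3 (0.04 log units; within the scatter) and it remains an estimate. Compound 3 is estimated at 38000 nM with an expected range from 15000 nM to 80000 nM in this assay.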

Compound 3, concentration for 50% growth inhibition: 28000 nM
Beside the measured number, compound 3's estimate is 1.4-fold (0.13 log units) above it; the measured number falls inside the stated range.
By their numbers in this assay, from the lowest: compounds 3, 1 and 2 (each within the scatter of the next).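

In this assay, within the data shown here, the place on a double-bonded chain carbon bound to a double-bonded chain carbon now carries three different groups, where the earlier compounds offered only a single exchange. The acetyl group reads alike with the cyano group, at a 1.5-fold lower number from compound 2 to compound 3 (0.18 log units; within the scatter), and alike with the tert-butoxycarbonyl group, at a 1.5-fold lower number from compound 1 to compound 3 (0.17 log units; within the scatter). The second of these steps is also a cleaner exchange, methyl in place of tert-butoxy on a carbonyl carbon, so two different groups on that carbonyl carbon leave the number within the scatter, and none of the three exchanges shown at this place moves it beyond the scatter. Nothing at hand explains why these three groups read alike.

The compounds shown leave open whether a carboxylic acid or an amine at this place would give a step beyond the scatter, since all three groups so far are a cyano group or carry a carbonyl. They also leave open whether a longer chain in place of the 2-acetylethenyl group would read alike with these three compounds.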